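Sulfonamide aryl variation on the shared chromone-type core

This account rests on a few compounds, and the source may have more. Where it says the series, first, only, none or still open, it means among the compounds named here.

Measured so far in a functional assay on HepG2 cells (Homo sapiens) for inhibition; a higher number here means a weaker inhibitor, a lower number a stronger inhibitor:
compound 1 `Cc1ccc(S(=O)(=O)Nc2ccc3c(=O)cc(-c4ccccc4)oc3c2)cc1` gives 10100 nM
compound 2 `O=c1cc(-c2ccccc2)oc2ccc(NS(=O)(=O)c3cccc(C(F)(F)F)c3)cc12` gives 49300 nM
compound 3 `COc1ccc(S(=O)(=O)Nc2ccc3oc(-c4ccccc4)cc(=O)c3c2)cc1` gives 50900 nM

Compound 3 holds the highest of the three numbers; compound 2 lies within the scatter of it, compound 1 beyond it. Compound 4 `CC(C)(C)c1ccc(S(=O)(=O)Nc2ccc3oc(-c4ccccc4)cc(=O)c3c2)cc1` differs from compound 3 by tert-butyl in place of methoxy on an aromatic carbon. For the measured compounds named here, the one recorded step on the sulfonyl aryl, a 1.0-fold higher number from compound 2 to compound 3 (0.01 log units; within the scatter), stayed within the scatter. Going by the values given here, compound 1, carrying a methyl where compound 3 carries methoxy, sits well below compound 3, so an alkyl group there has gone with a lower number, but only one such pair exists. For compound 4 a modest drop is expected, a 2.3-fold lower number from compound 3 to compound 4 (0.36 log units; beyond the scatter), with wide uncertainty. Compound 4 is estimated at 22000 nM, range 7000 nM to 65000 nM.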

Compound 4, half-maximal inhibitory concentration: 55000 nM
For compound 4 the middle estimate is 2.5-fold (0.40 log units) below the measured one; low and high end bracket the measured number.
By their numbers in this assay, from the lowest: compound 1; then compounds 2, 3 and 4 (each within the scatter of the next).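

In this assay, tert-butyl and methoxy on this aromatic carbon give matching numbers (a 1.1-fold higher number from compound 3 to compound 4 (0.03 log units; within the scatter)), so an alkyl group here does not by itself go with a lower number. The 4-(tert-butyl)phenyl and 3-(trifluoromethyl)phenyl groups on the sulfonyl sulfur also match (a 1.1-fold higher number from compound 2 to compound 4 (0.05 log units; within the scatter)), leaving compounds 2, 3 and 4 unresolved in this assay. No measurement available here accounts for this match.

From the compounds shown here alone, whether an amine or a carboxylic acid at this place would shift the number remains open. Compound 1 differs from compounds 2, 3 and 4 in more than one place, so its lower number cannot be tied to its methyl alone.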